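The source may report more compounds than this note shows. Statements on the series, on what has been measured and on what is new or still open speak of the compounds shown alone.

Three amides sharing one core have been tested in a functional assay on HCT-116 cells (Homo sapiens) for antiproliferative activity, read by MTT assay, with a stated time of 72 h; a lower number here means a stronger inhibitor, a higher number a weaker inhibitor. Compound 1 `CC(C)(C)NC(=O)CCc1cccc2c1B(O)OC2`, with a tert-butyl group on the amide nitrogen, gives > 100000 nM, which is a limit of the assay and not a number. Compound 2 `Cc1ccc(NC(=O)CCc2cccc3c2B(O)OC3)cc1`, with 4-methylphenyl on that nitrogen, gives 4500 nM. Compound 3 `O=C(CCc1cccc2c1B(O)OC2)Nc1cccc(Br)c1`, with 3-bromophenyl there, gives 1400 nM, the lowest number among the three.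

Compound 4 `Cc1ccc(NC(=O)CCc2cccc3c2B(O)OC3)cc1Br` differs from compound 3 in one place: methyl in place of hydrogen on an aromatic carbon. The methyl replaces a hydrogen on an aromatic carbon, ortho to a bromo group and para to a large group.

Replacing tert-butyl with an aromatic group brought large steps, an at least 22-fold lower number from compound 1 to compound 2 (1.34 log units; beyond the scatter) and an at least 71-fold lower number from compound 1 to compound 3 (1.85 log units; beyond the scatter), but these exchange a whole group and bear only loosely on a single added methyl. Closer is the modest 3.2-fold lower number from compound 2 to compound 3 (0.51 log units; beyond the scatter), which exchanges one substituted phenyl group for another, the first of them bearing a methyl. Within the data shown here, no measured step adds a methyl alone. In this assay, therefore, no step beyond the scatter is expected, in either direction. The estimated step is a 1.1-fold lower number from compound 3 to compound 4 (0.03 log units; within the scatter). The value expected for compound 4 is 1300 nM, with an estimated range from 450 nM to 3800 nM.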

Compound 4, half-maximal inhibitory concentration: 1200 nM
The estimate for compound 4 lay 1.1-fold (0.03 log units) above the measured number; measured number inside the range.
By their numbers in this assay, from the lowest: compounds 4 and 3 (each within the scatter of the next); then compound 2. At a limit, above all of these: compound 1.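

In this assay, methyl on this aromatic carbon, ortho to a bromo group and para to a large group, is tolerated, with a 1.2-fold lower number from compound 3 to compound 4 (0.07 log units; within the scatter), so the bromo-bearing phenyl group accepts the added methyl without a change that can be told from the scatter. Among these compounds, the same compound also gives the first measured step for bromo alone, with the methyl held in place: a 3.8-fold lower number from compound 2 to compound 4 (0.57 log units; beyond the scatter), close in size to the earlier 3.2-fold lower number from compound 2 to compound 3 (0.51 log units; beyond the scatter), which exchanged one substituted phenyl group for another and so could not separate the two groups. Nothing measured here gives a cause for either step.

The compounds shown do not tell whether a larger group at this carbon, such as ethyl or methoxy, or a group of another kind, such as an amine or a carboxylic acid, would also leave the number within the scatter. They also leave open whether chloro would serve in place of bromo, and what a longer chain carrying the amide would do to the numbers in this assay.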